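Pyridin-3-yl to Pyridin-4-yl on the Carbonyl Carbon

This account rests on a few compounds, and the source may have more. Where it says the series, first, only, none or still open, it means among the compounds named here.

Measured compounds, growth inhibition in a functional assay on HepG2 cells (Homo sapiens) for inhibition, read by MTT assay, with a stated time of 48 h; on this read-out higher numbers stand for weaker inhibition of growth and lower numbers for stronger inhibition of growth:
compound 1 `Cn1cc(C2CC(c3ccccc3)=NN2C(=O)c2cccnc2)c2ccccc21` gives 4630 nM
compound 2 `Cn1cc(C2CC(c3ccccc3)=NN2C(=O)c2ccncc2)c2ccccc21` gives 630 nM
compound 3 `COc1ccc(C2=NN(C(=O)c3cccnc3)C(c3cn(C)c4ccc(Br)cc34)C2)cc1OC` gives 2450 nM

Compound 1 and compound 2 share one core and differ only at the carbonyl carbon: pyridin-4-yl in place of pyridin-3-yl on a carbonyl carbon. That single change made a 7.3-fold lower number from compound 1 to compound 2 (0.87 log units; beyond the scatter).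

Compound 3 carries a different core, with a bromo-substituted indole and a dimethoxyphenyl, but the same (pyridin-3-yl)carbonyl as compound 1; how its core differs from that of compound 1 is not broken down here. In this assay compound 3 sits close to compound 1, within the scatter, and gives a higher number than compound 2.

Compound 4 `COc1ccc(C2=NN(C(=O)c3ccncc3)C(c3cn(C)c4ccc(Br)cc34)C2)cc1OC` is not yet measured. It stands to compound 3 as compound 2 stands to compound 1: pyridin-4-yl in place of pyridin-3-yl on a carbonyl carbon. The place is the same kind of place, a carbonyl carbon whose other neighbour is an amide-type nitrogen in a ring, so this is the same kind of change. Within the data shown here, because the only earlier instance, a 7.3-fold lower number from compound 1 to compound 2 (0.87 log units; beyond the scatter), was beyond the scatter, a step of like direction is expected here, though with one precedent on a different core its size is less certain. Compound 4 is therefore expected to show a 4.9-fold lower number from compound 3 to compound 4 (0.69 log units; beyond the scatter), and its number in this assay is estimated at 500 nM, most likely between 150 nM and 1600 nM.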

Compound 4, concentration for 50% growth inhibition: > 10000 nM
Compound 4 gave a limit, no number; the forecaster's own chance of this, stated with the estimate: 3%; middle value at least 20-fold (1.30 log units) away from the limit.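

In this assay compound 4 gives > 10000 nM, which is a limit of the assay and not a number. On the core of compound 3, the change from pyridin-3-yl to pyridin-4-yl on a carbonyl carbon made an at least 4.0-fold higher number from compound 3 to compound 4 (0.61 log units; beyond the scatter), so the direction seen on the core of compound 1 did not carry over, and the same change cannot be treated as transferable between these two cores: the same change on two cores in this assay, a 7.3-fold lower number (0.87 log units; beyond the scatter) from compound 1 to compound 2 and an at least 4.0-fold higher number (0.61 log units; beyond the scatter) from compound 3 to compound 4, at least 29-fold (1.47 log units) apart, beyond the scatter of two such steps. This rests on just two pairs, and it does not show which part of the core difference, the bromo substituent or the dimethoxyphenyl, goes with the reversal, nor the full size of the step, which is bounded by a limit: the limit of > 10000 nM in this assay, at which 1 of the 4 values shown sits.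

The compounds shown leave open whether the pyridin-4-yl step would keep the direction seen on the core of compound 1 or that seen on the core of compound 3 if the bromo substituent and the dimethoxyphenyl were present one at a time. They also leave open how a pyridin-2-yl or a plain phenyl on the same carbonyl carbon would compare with the two pyridine groups on either core.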